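Dimethoxyphenyl replacing dimethylaminophenyl on a cytotoxicity-inactive series

A few compounds are considered here, and "the series" means these few. Any claim that something is new, unique, unknown or untested is made for them only; others in the source may bear on it.

Compound 1 `CC(C)N(Cc1cccc(OCCCCCC(=O)O)c1)C(=O)c1ccc(-c2cccc(N(C)C)c2)cc1` in an ADME assay on Raji cells (Homo sapiens) for cytotoxicity, read by CellTiter-Glo and resazurin assay, with a stated time of 72 h (on this read-out lower numbers stand for an effect already at smaller amounts and higher numbers for an effect only at larger amounts of compound), gives > 26000 nM, which is a limit of the assay.
Compound 2 `CC(C)N(Cc1cccc(OCCCCCC(=O)O)c1)C(=O)c1ccc(-c2cccc([N+](=O)[O-])c2)cc1` in this assay gives > 26000 nM, which is a limit of the assay.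
Compound 3 `CCOC(=O)CCCCCOc1cccc(CN(C(=O)c2ccc(-c3cccc(N(C)C)c3)cc2)C(C)C)c1` in this assay gives > 26000 nM, which is a limit of the assay.

Compound 3 therefore stands at the limit of > 26000 nM in this assay, at which 3 of the 3 values shown sit, and no value shown sets any compound apart from it. Two steps between measured compounds exist: a step that the two limits leave unreadable from compound 1 to compound 2 and a step that the two limits leave unreadable from compound 1 to compound 3. Neither is readable, since each runs from one limit to another, so neither shows a direction or a size.

Compound 4 `CCOC(=O)CCCCCOc1cccc(CN(C(=O)c2ccc(-c3cc(OC)cc(OC)c3)cc2)C(C)C)c1` is the next compound to be measured. It differs from compound 3 by 3,5-dimethoxyphenyl in place of 3-(dimethylamino)phenyl on an aromatic carbon. For the measured compounds named here, no measured step involves this change, and the steps that were measured give no size or direction to build on. The only pattern shown is that every measured compound rests at the limit, with nothing going against it among compounds 1, 2 and 3. Compound 4 is accordingly expected to rest at the limit as well, and the step that the limit leaves unreadable from compound 3 to compound 4 is expected to carry no readable size. Compound 4 is estimated at 40000 nM, with a range from 20000 nM to 100000 nM.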

Compound 4, half-maximal effective concentration: > 26000 nM
Compound 4 ended at the assay's limit; the forecaster's own chance of this, stated with the estimate: 85%; the middle value does not contradict the limit.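

The step between compound 3 and compound 4 cannot be read, since each rests on a limit in this assay and shows neither direction nor size: the limit of > 26000 nM in this assay, at which 4 of the 4 values shown sit.

The compounds shown leave open whether any change to the shared core would give a value off that limit.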